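A few compounds are considered here, and "the series" means these few. Any claim that something is new, unique, unknown or untested is made for them only; others in the source may bear on it.

Compound 1 `C=C(Br)C(=O)Nc1ccc(/C=C/C(=O)c2ccc(OCC)cc2)cc1` gives 750 nM in a functional assay on HeLa cells (Homo sapiens) for antiproliferative activity, with a stated time of 48 h; a higher number here means a weaker inhibitor, a lower number a stronger inhibitor
Compound 2 `C=C(Br)C(=O)Nc1ccc(C(=O)/C=C/c2ccccc2)cc1` gives 960 nM in this assay
Compound 3 `C=C(Br)C(=O)Nc1ccc(C(=O)/C=C/c2cccc(OC)c2)cc1` gives 500 nM in this assay

In this assay the value of compound 3 lies within the usual scatter of the values of compound 1 and compound 2, so these numbers do not rank the three compounds. Compound 4 `C=C(Br)C(=O)Nc1ccc(C(=O)/C=C/c2cccc(OC)c2OC)cc1` differs from compound 3 by a single change, methoxy in place of hydrogen on an aromatic carbon (methoxy in place of hydrogen on an aromatic carbon, ortho to a large group and ortho to a methoxy group).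

Among the measured compounds shown here, one measured step bears on this change. For the measured compounds named here, it is the same kind of replacement, a 1.9-fold lower number from compound 2 to compound 3 (0.28 log units; within the scatter) (within the scatter), but no measured compound carries a methoxy group on this particular carbon, so it is only a loose guide. A second methoxy group is therefore not expected to produce a step beyond the scatter in this assay in either direction. The estimated change is no change at the digits printed from compound 3 to compound 4 (within the scatter) (that is, no real shift is expected). With so little evidence, the expected range is kept wide. For compound 4 the estimated value is 500 nM (expected range 200 nM to 1300 nM) and the measurement will show where it actually falls.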

Compound 4, half-maximal inhibitory concentration: 380 nM
For compound 4 the middle estimate is 1.3-fold (0.12 log units) above the measured one, and the stated range covers the measured number.
By their numbers in this assay, from the lowest: compounds 4, 3, 1 and 2 (each within the scatter of the next, the first and the last beyond it).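

In this assay the methoxy group placed on the carbon ortho to a large group and ortho to a methoxy group gives a 1.3-fold lower number from compound 3 to compound 4 (0.12 log units; within the scatter) and so causes no real shift. Among the compounds shown here, this is the first reading at this carbon, as none of the earlier compounds carries a group there, and it shows that the ring can hold the second methoxy group without leaving the scatter. The same replacement, seen earlier as a 1.9-fold lower number from compound 2 to compound 3 (0.28 log units; within the scatter), has now been read at two carbons of this ring and stays within the scatter at both, though nothing at hand accounts for this outcome.

The compounds shown leave open whether an amine or a carboxylic acid on this carbon would also stay within the scatter, and whether a longer chain such as ethoxy in place of the methoxy group would do the same. They also leave open whether a fluorine or chlorine atom on this carbon would give a step beyond the scatter in either direction.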